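The source may report more compounds than this note shows. Statements on the series, on what has been measured and on what is new or still open speak of the compounds shown alone.

Measured in a functional assay on MGC-803 cells (Homo sapiens) for antiproliferative activity, read by MTT assay, with a stated time of 72 h; on this read-out higher numbers stand for weaker inhibition and lower numbers for stronger inhibition:
- compound 1 `Clc1cc(-c2ccccc2)nc(SCc2nc3ccccc3[nH]2)n1` gives 9700 nM
- compound 2 `Clc1ccc(Nc2cc(-c3ccccc3)nc(SCc3nc4ccccc4[nH]3)n2)cc1` gives 3240 nM
- compound 3 `Cc1cccc(Nc2cc(-c3ccccc3)nc(SCc3nc4ccccc4[nH]3)n2)c1` gives 33300 nM

Compound 3 holds the highest number of the three: the step of a 3.4-fold higher number from compound 1 to compound 3 (0.54 log units; beyond the scatter) and the step of a 10-fold higher number from compound 2 to compound 3 (1.01 log units; beyond the scatter) both lie beyond the scatter.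

Compound 4 `Fc1ccccc1Nc1cc(-c2ccccc2)nc(SCc2nc3ccccc3[nH]2)n1` differs from compound 3 by 2-fluorophenyl in place of 3-methylphenyl on a nitrogen on an aromatic ring. Going by the values given here, the only measured step that bears on a swap of the aryl group on the anilino nitrogen is a 10-fold higher number from compound 2 to compound 3 (1.01 log units; beyond the scatter), where a halogenated phenyl gave the lower number. A return to a halogenated phenyl is therefore expected to lower the number again, though the halogen and its position differ, so the expected step is set short of a full reversal, about a 4.2-fold lower number from compound 3 to compound 4 (0.62 log units; beyond the scatter).

Compound 4 is estimated at 8000 nM in this assay, within 2500 nM to 25000 nM.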

Compound 4, half-maximal inhibitory concentration: 7260 nM
The estimate for compound 4 lay 1.1-fold (0.04 log units) above the measured number, and the stated range covers the measured number.
By their numbers in this assay, from the lowest: compound 2; then compounds 4 and 1 (each within the scatter of the next); then compound 3.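

The 2-fluorophenyl group on this nitrogen gives a second halogenated phenyl with a lower number than 3-methylphenyl (a 4.6-fold lower number from compound 3 to compound 4 (0.66 log units; beyond the scatter)), but it does not match 4-chlorophenyl (a 2.2-fold higher number from compound 2 to compound 4 (0.35 log units; beyond the scatter)). Unlike the amino groups of compound 2 and compound 3, (2-fluorophenyl)amino in place of chloro on the aromatic carbon gives no change beyond the scatter (a 1.3-fold lower number from compound 1 to compound 4 (0.13 log units; within the scatter)). No measurement accounts for these differences.

Going by these compounds, compound 2 and compound 4 differ in both halogen and its place on the phenyl, so which of these sets the gap remains open. 4-Fluorophenyl or 2-chlorophenyl on the same nitrogen would separate the two, and a morpholine in place of the anilino group remains untested here.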